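The source may hold more compounds than are shown below. What is called first, only, known or untested is meant among the compounds shown, and "the series" means these compounds.

Measured so far:
compound 1, `CCCCCc1c(C(C)C)nc(C(C)C)c(CO)c1-c1ccc(OC)cc1`, 37%
compound 2, `CCCCCc1c(C(C)C)nc(C(C)C)c(CO)c1-c1cccc2ccccc12`, 6%
compound 3, `CCC/C=C/c1c(C(C)C)nc(C(C)C)c(CO)c1-c1ccc(Cl)c(Cl)c1`, 39%

In an assay on CHO cells for inhibition of Glucagon receptor (Homo sapiens), tested at 20 uM (a higher number here means more inhibition at the concentration tested (going by the name of the read-out), a lower number less inhibition), compound 1 gives 37%, the second highest of the three numbers. Its nearest neighbour is compound 3 with 39%, a gap within the usual scatter, so the two cannot be told apart. Its furthest neighbour is compound 2 with 6%, a gap well beyond the scatter, so compound 2 inhibits clearly less than compound 1 at the tested concentration. Within the data shown here, no pair of measured compounds differs in only one place, so no single structural step has been isolated in this assay.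

The piece now turns to compound 4, `CCCCCc1c(C(C)C)nc(C(C)C)c(CO)c1-c1ccc(Cl)cc1Cl`, which is not yet measured. Compound 4 differs from compound 1 in one place: 2,4-dichlorophenyl in place of 4-methoxyphenyl on an aromatic carbon. Compound 3 carries a dichlorophenyl group together with a different chain and sits close to compound 1, which offers some comfort that two chlorines on the phenyl do not ruin inhibition, but no clean comparison exists.

The step expected in this assay is small and in no clear direction, not beyond the scatter. Compound 4 is therefore estimated at 36%, within a range from 15% to 56%. The step this estimate means is a number 1 percentage points lower from compound 1 to compound 4 (within the scatter).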

Compound 4, a percentage reported as inhibition, at one concentration (the size of the read-out at that concentration, not a potency): 8%
Beside the measured number, compound 4's estimate is 28 percentage points above it, outside the stated range (below it).
By their numbers in this assay, from the lowest: compounds 2 and 4 (each within the scatter of the next); then compounds 1 and 3 (each within the scatter of the next).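

On the aromatic carbon opposite the ring nitrogen, ortho to the hydroxymethyl and pentyl groups, the choice of aryl group clearly matters in this assay: replacing 4-methoxyphenyl with 2,4-dichlorophenyl gives a number 29 percentage points lower from compound 1 to compound 4 (beyond the scatter). Among these compounds, this is the first single change read, and it shows that inhibition at this position can fall sharply even though the entering and leaving groups have the same heavy-atom count and each carries one six-membered aromatic ring; the counted difference is that the single hydrogen-bond acceptor of the 4-methoxyphenyl group is absent from the 2,4-dichlorophenyl group. No measurement shown here accounts for the loss.

The step changes several features at once, so the compounds shown do not separate the loss of the methoxy group from the arrival of either chlorine. A 4-chlorophenyl group or a 2-chlorophenyl group at this position on the same pentyl-bearing core would tell whether the chlorine opposite the point of attachment or the one closest to it goes with the low value.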